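Methoxy addition on two indole cores; estimate for compound 4

This account rests on a few compounds, and the source may have more. Where it says the series, first, only, none or still open, it means among the compounds named here.

Compound 1 `COc1ccc(-c2[nH]c3ccccc3c2/C=C(\C#N)S(=O)(=O)c2ccccc2)cc1` gives 1200 nM in a functional assay on 786-0 cells (Homo sapiens) for inhibition, read by sulforhodamine B assay, with a stated time of 48 h; on this read-out higher numbers stand for weaker inhibition of growth and lower numbers for stronger inhibition of growth. Compound 3 `COc1ccc(-c2[nH]c3ccc(OC)cc3c2/C=C(\C#N)S(=O)(=O)c2ccccc2)cc1` carries the change (methoxy in place of hydrogen on an aromatic carbon), its place being on an aromatic carbon of a six-membered aromatic ring of carbon only, part of a fused or bridged system of two rings, meta to a fused ring and para to a fused ring; in this assay compound 3 gives 2100 nM, the step of a 1.8-fold higher number from compound 1 to compound 3 (0.24 log units; within the scatter). Compound 2 `COc1ccc2[nH]c(-c3ccccc3)c(C=C(C#N)C#N)c2c1` gives 6600 nM in this assay; the difference between the core of compound 2 and the core of compound 1 is not broken down here. Compound 4 `COc1ccc(-c2[nH]c3ccc(OC)cc3c2C=C(C#N)C#N)cc1` carries the same kind of change, (methoxy in place of hydrogen on an aromatic carbon), but here the place is on an aromatic carbon of a six-membered aromatic ring of carbon only, para to a large group, so the surroundings are not the same as in compound 3. Since the step of a 1.8-fold higher number from compound 1 to compound 3 (0.24 log units; within the scatter) stayed within the scatter, compound 4 is expected to stay near compound 2, with an estimated step of a 1.4-fold higher number from compound 2 to compound 4 (0.13 log units; within the scatter) in this assay. For compound 4 the estimate in this assay is 9000 nM, between 4000 nM and 25000 nM.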

Compound 4, concentration for 50% growth inhibition: 14300 nM
Estimate against measurement, compound 4: 1.6-fold (0.20 log units) below; the range from low to high includes it.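

In this assay, methoxy in place of hydrogen gives a 2.2-fold higher number from compound 2 to compound 4 (0.34 log units; beyond the scatter), a modest loss of growth inhibition. Set beside the earlier step, the change carries from one core to the other with no difference that can be told apart: the same change on two cores in this assay, a 1.8-fold higher number (0.24 log units; within the scatter) from compound 1 to compound 3 and a 2.2-fold higher number (0.34 log units; beyond the scatter) from compound 2 to compound 4, 1.2-fold (0.09 log units) apart, within the scatter of two such steps

Among the compounds shown here, this does not show a fixed effect of the change, since each core supplies a single pair, the methoxy enters at a different place in each pair, and only the step on the core of compound 2 lies beyond the scatter.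

Still open, from the compounds shown here alone, is how either core responds to other groups at these places, such as a hydroxyl, an amine, a carboxylic acid or a longer chain like butoxy in place of methoxy. Also open, going by these compounds, is whether the step from phenyl to 4-methoxyphenyl has the same size on the core of compound 1 when the other methoxy is absent.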